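Swapping Azido for Hydroxy on a Selenium Sugar Ring

A few compounds are considered here, and "the series" means these few. Any claim that something is new, unique, unknown or untested is made for them only; others in the source may bear on it.

Compound 1 `Cc1cn(C2[Se][C@H](CO)[C@@H](O)[C@@H]2N=[N+]=[N-])c(=O)[nH]c1=O`: in a functional assay on PC-3 cells (Homo sapiens) for cytotoxicity, read by sulforhodamine B assay (a higher number here means a weaker inhibitor, a lower number a stronger inhibitor), compound 1 gives > 100000 nM, a limit of the assay and not a number.
Compound 2 `Cc1cn(C2[Se][C@H](CO)[C@@H](O)[C@@H]2O)c(=O)[nH]c1=O`: in this assay compound 2 gives > 100000 nM, again a limit and not a number.
Among the measured compounds shown here, compound 3 `[N-]=[N+]=N[C@@H]1C(n2ccc(N)nc2=O)[Se][C@H](CO)[C@H]1O`: in this assay compound 3 gives 75100 nM, the only number of the three.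

Compound 1 and compound 2 differ by hydroxy in place of azido on a saturated ring carbon. The step that the two limits leave unreadable from compound 1 to compound 2 is left unreadable by the limit of > 100000 nM in this assay, at which 2 of the 3 values shown sit, so how much this swap changes cytotoxicity is not known from these two. How the core of compound 3 differs from the core of compound 1 is not broken down here.

Compound 4 `Nc1ccn(C2[Se][C@H](CO)[C@@H](O)[C@@H]2O)c(=O)n1` has not been measured yet. It differs from compound 3 by hydroxy in place of azido on a saturated ring carbon. The surroundings are not identical: in compound 3 the carbon sits next to the ring atom that bears a group of 8 heavy atoms, whereas in compound 1 that neighbour bears a group of 9 heavy atoms, so this is the same kind of change, not the same change. With the earlier step unreadable, the expectation rests only on compound 3 sitting at 75100 nM, and the step from compound 3 to compound 4 is estimated as a 1.6-fold higher number from compound 3 to compound 4 (0.20 log units; within the scatter). Compound 4 is expected to give about 120000 nM in this assay, most likely reported as a limit, with 40000 nM to 400000 nM as the plausible range.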

Compound 4, half-maximal inhibitory concentration: 4540 nM
Compound 4: the middle estimate sits 26-fold (1.42 log units) above what was measured; measured number below the stated range.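

On the core of compound 3, putting hydroxy in place of azido on a saturated ring carbon gives a 17-fold lower number from compound 3 to compound 4 (1.22 log units; beyond the scatter) in this assay, so on this core the swap goes with a clearly stronger result. The same swap on the core of compound 1 gives no readable step, because compound 1 and compound 2 both stand at a limit and not at a number: the limit of > 100000 nM in this assay, at which 2 of the 4 values shown sit. This makes the step from compound 3 to compound 4 the only readable case of the change, so it shows what the swap does on one core and does not show whether that result carries over to the other.

The compounds shown leave open whether a different group on that ring carbon, such as an amine or a single fluorine atom, would match hydroxy on the core of compound 3. They also leave open what a carboxylic acid in place of the hydroxymethyl group would do on that core.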